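A Shorter Amide Chain and Its Expected Effect

The source may report more compounds than this note shows. Statements on the series, on what has been measured and on what is new or still open speak of the compounds shown alone.

Of the compounds shown here, three sharing one core have been measured in a functional assay, with a stated time of 15 min; on this read-out higher numbers stand for an effect only at larger amounts of compound and lower numbers for an effect already at smaller amounts. Compound 1, `Nc1ccc(OCc2ccccc2)c2ccccc12`, gives 7000 nM. Compound 2, `CCCCCCCCCC(=O)Nc1ccc(O)c2ccccc12`, gives 18000 nM, the highest of the three numbers. Compound 3, `Cc1ccc(S(=O)(=O)Nc2ccc(O)c3ccccc23)cc1`, gives 16000 nM, which lies within the usual scatter of the number for compound 2, so the two cannot be told apart. Compound 1, by contrast, sits beyond the scatter from compound 2, with a clearly lower number, meaning its effect appears at smaller amounts.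

The next compound, compound 4, `CCC(=O)Nc1ccc(O)c2ccccc12`, is derived from compound 2 by one change: hydrogen in place of heptyl on a saturated chain carbon, two bonds along the chain from a carbonyl carbon. The amide is kept, only its chain is cut back. Within the data shown here, no measured pair in this set shows what such a chain shortening does on its own, so the expectation rests on the weak numbers of compounds 2 and 3 alone. A step from compound 2 to compound 4 of about a 1.1-fold higher number from compound 2 to compound 4 (0.05 log units; within the scatter) is expected, that is, little beyond the scatter in either direction. Compound 4 is therefore estimated at 20000 nM in this assay, within a range of 7000 nM to 60000 nM.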

Compound 4, half-maximal effective concentration: 16000 nM
The estimate for compound 4 lay 1.3-fold (0.10 log units) above the measured number; the measured number falls inside the stated range.
By their numbers in this assay, from the lowest: compound 1; then compounds 3, 4 and 2 (each within the scatter of the next).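

In this assay, putting hydrogen in place of heptyl on a saturated chain carbon, two bonds along the chain from a carbonyl carbon, gives a 1.1-fold lower number from compound 2 to compound 4 (0.05 log units; within the scatter) and leaves the two compounds indistinguishable. Among these compounds, this is the first single change measured in the set, and it shows that, on this amide, removing the heptyl group has no effect that can be told from the scatter. No measurement shown explains why the number stays put.

As far as these compounds go, whether another group at this place, such as an amine, a carboxylic acid or a phenyl ring, would move the number beyond the scatter remains open. From the compounds shown here alone, compound 1 differs from the others in more than one place, so which of those differences goes with its lower number is also open.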